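Swapping a Hydroxymethyl for an Ethoxycarbonyl on the Outer Ring

This account rests on a few compounds, and the source may have more. Where it says the series, first, only, none or still open, it means among the compounds named here.

Of the compounds shown here, two sharing the same core have been tested so far. Compound 1 `CCOc1ccc(-c2ccc(N(C[C@@H](N)[C@@H](C)CC)C(=O)[C@@H]3C[C@H]3c3ccccc3)cc2)cc1` carries an ethoxy group on the outer aromatic ring, and in a functional assay for agonist activity at G protein-coupled receptor 88 (Homo sapiens), read by HTRF and cAMP accumulation (a higher number here means that more compound is needed for the effect, a lower number that less compound is needed), compound 1 gives 90 nM. Compound 2 `CC[C@H](C)[C@H](N)CN(C(=O)[C@@H]1C[C@H]1c1ccccc1)c1ccc(-c2ccc(CO)cc2)cc1` carries a hydroxymethyl group in the same position, and in this assay compound 2 gives 1100 nM. That single exchange gave a 12-fold higher number from compound 1 to compound 2 (1.09 log units; beyond the scatter), so compound 2 stands at the higher of the two numbers, meaning more compound is needed for the effect.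

Compound 3 `CCOC(=O)c1ccc(-c2ccc(N(C[C@@H](N)[C@@H](C)CC)C(=O)[C@@H]3C[C@H]3c3ccccc3)cc2)cc1` is not yet measured. It differs from compound 2 by ethoxycarbonyl in place of hydroxymethyl on an aromatic carbon. The ethoxycarbonyl brings back the ethyl chain seen in compound 1 and removes the hydrogen-bond donor, though as an ester it is not an ethoxy. Going by the values given here, the only step that bears on this is the large one from compound 1 to compound 2, which suggests the hydroxymethyl was the weaker choice. Compound 3 is therefore expected to move back toward compound 1 with a step of a 4.4-fold lower number from compound 2 to compound 3 (0.64 log units; beyond the scatter), with considerable uncertainty. The estimate for compound 3 in this assay is 250 nM, ranging from 60 nM to 1000 nM.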

Compound 3, half-maximal effective concentration: 260 nM
The estimate for compound 3 lay 1.0-fold (0.02 log units) below the measured number, and the stated range covers the measured number.
By their numbers in this assay, from the lowest: compound 1; then compound 3; then compound 2.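

In this assay, this position now shows three distinct levels rather than a simple contrast between a better and a worse group. The ethoxycarbonyl recovers much of what was lost with the hydroxymethyl, with a 4.2-fold lower number from compound 2 to compound 3 (0.63 log units; beyond the scatter), but it does not fully match the ethoxy, with a 2.9-fold higher number from compound 1 to compound 3 (0.46 log units; beyond the scatter). Among these three compounds, the two groups carrying an ethyl chain both give lower numbers than the hydroxymethyl, and none goes against this, yet the ethyl chain alone does not set the level, as compound 1 and compound 3 remain apart by more than the scatter.

No measurement here explains why these groups differ. In the step to the ethoxycarbonyl, the hydrogen-bond donor leaves and the ethyl chain enters together, so these compounds cannot separate the two changes; a comparison with a methoxycarbonyl, a carboxylic acid or a longer propoxy chain at this position would help to tell them apart.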